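A few compounds are considered here, and "the series" means these few. Any claim that something is new, unique, unknown or untested is made for them only; others in the source may bear on it.

Measured in a functional assay for inhibition, with Homo sapiens as the target; a higher number here means a weaker inhibitor, a lower number a stronger inhibitor:
- Compound 1 `CC(C)(O)c1cc(-c2ccccc2)c2ccc(OCc3cccc(C4(O)CCOCC4)c3)cc2c1` gives 59 nM
- Compound 2 `COC(=O)c1cc(-c2ccccc2)c2ccc(OCc3cccc(C4(O)CCOCC4)c3)cc2c1` gives 3 nM
- Compound 3 `N#Cc1cc(-c2ccccc2)c2ccc(OCc3cccc(C4(O)CCOCC4)c3)cc2c1` gives 3 nM

Compound 3 stands level with compound 2, the two sharing the lowest number of the three, while compound 1 sits well above them. Compound 4 `Cn1nnc(-c2cc(-c3ccccc3)c3ccc(OCc4cccc(C5(O)CCOCC5)c4)cc3c2)n1` keeps the shared core and alters one group: 2-methyl-2H-tetrazol-5-yl in place of cyano on an aromatic carbon, which amounts to 2-methyl-2H-tetrazol-5-yl in place of cyano on an aromatic carbon.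

All three measured steps concern this same position. Methoxycarbonyl in place of 1-hydroxy-1-methylethyl gave a 20-fold lower number from compound 1 to compound 2 (1.29 log units; beyond the scatter), and cyano in place of 1-hydroxy-1-methylethyl gave a 20-fold lower number from compound 1 to compound 3 (1.29 log units; beyond the scatter), both large steps. Cyano in place of methoxycarbonyl gave no change at the digits printed from compound 2 to compound 3 (within the scatter), so these two different groups cannot be told apart in this assay. For the measured compounds named here, that match suggests that compound 4 may also stay close to compound 3, although no measured compound carries a tetrazole ring, which leaves real uncertainty and a risk of a weaker result. The expected change is a 1.7-fold higher number from compound 3 to compound 4 (0.22 log units; within the scatter), a small step towards a higher number that probably stays within the scatter. For compound 4 the estimate is 5 nM, with an expected range from 1.5 nM to 25 nM.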

Compound 4, half-maximal inhibitory concentration: 4 nM
The estimate for compound 4 lay 1.3-fold (0.10 log units) above the measured number, and the stated range covers the measured number.
By their numbers in this assay, from the lowest: compounds 2, 3 and 4 (each within the scatter of the next); then compound 1.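

In this assay, this position takes a far larger group than cyano without a change beyond the scatter: 2-methyl-2H-tetrazol-5-yl, with its five-membered aromatic ring carrying 4 hetero atoms, gives a 1.3-fold higher number from compound 3 to compound 4 (0.12 log units; within the scatter) and a 1.3-fold higher number from compound 2 to compound 4 (0.12 log units; within the scatter), so compound 2, compound 3 and compound 4 cannot be told apart. The comparison with 1-hydroxy-1-methylethyl also holds for this ring-bearing group, which gives a 15-fold lower number from compound 1 to compound 4 (1.17 log units; beyond the scatter), leaving compound 1 as the only one of the four set apart from the others. No measurement offered here explains why three such different groups give numbers this close, or why compound 1 stands apart.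

The compounds shown leave open whether an amine, a carboxylic acid or a primary amide at this position would group with compound 2, compound 3 and compound 4, or with compound 1. On these data alone, it is also open whether the methyl on the tetrazole ring matters, as a comparison with an ethyl group or a longer chain in its place would show.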